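A few compounds are considered here, and "the series" means these few. Any claim that something is new, unique, unknown or untested is made for them only; others in the source may bear on it.

Measured compounds in a functional assay on K562 cells (Homo sapiens) for cytotoxicity, read by trypan blue exclusion, with a stated time of 96 h; a higher number here means a weaker inhibitor, a lower number a stronger inhibitor:
compound 1 `COc1ccc(NS(=O)(=O)/C=C/c2c(F)c(F)c(F)c(F)c2F)cc1` gives 5000 nM;
compound 2 `COc1cc(OC)c(/C=C/S(=O)(=O)Nc2ccc(OC)c(OP(=O)(O)O)c2)c(OC)c1` gives 7.5 nM;
compound 3 `COC(=O)C(C)(C)Nc1cc(NS(=O)(=O)/C=C/c2c(OC)cc(OC)cc2OC)ccc1OC` gives 300 nM.

Among these three numbers compound 3 stands second highest: compound 1 sits well above it and compound 2 sits far below it, both gaps beyond the scatter. Compound 4 `COc1cc(OC)c(/C=C/S(=O)(=O)Nc2ccc(OC)c(NC(C(=O)O)c3ccc(Br)cc3)c2)c(OC)c1` differs from compound 3 in one place: (4-bromophenyl)(carboxy)methyl in place of 1-(methoxycarbonyl)-1-methylethyl on a nitrogen on an aromatic ring. Going by the values given here, the only measured step that alters a substituent on the same aromatic carbon is a 40-fold higher number from compound 2 to compound 3 (1.60 log units; beyond the scatter), a large one, but it swapped a different pair of groups, so it gives a direction only in the sense that this assay is sensitive to changes there. Compound 4 is expected to give 250 nM, with a range from 40 nM to 1500 nM. That estimate amounts to an expected step of a 1.2-fold lower number from compound 3 to compound 4 (0.08 log units; within the scatter), not confidently beyond the scatter.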

Compound 4, half-maximal inhibitory concentration: 75 nM
Beside the measured number, compound 4's estimate is 3.3-fold (0.52 log units) above it, and the stated range covers the measured number.
By their numbers in this assay, from the lowest: compound 2; then compound 4; then compound 3; then compound 1.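

In this assay the change on the nitrogen gives a 4.0-fold lower number from compound 3 to compound 4 (0.60 log units; beyond the scatter), so this position accepts the larger (4-bromophenyl)(carboxy)methyl, with its aromatic ring, and the number still falls. Even so, the phosphate on the same aromatic carbon remains ahead, with a 10-fold higher number from compound 2 to compound 4 (1.00 log units; beyond the scatter). The data shown offer no measured explanation for either step. The compounds shown leave open whether the carboxylic acid, the bromine or the aromatic ring accounts for the drop, and how an unsubstituted amine or a longer chain would compare.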